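Metabolic stability notes: carboxycyclohexyl to dioxothianyl amides

The compounds below may be only part of what the source reports. "The series", "measured", "known", "first", "only" and "open" are said of these compounds alone.

Measured compounds:
- compound 1 `CO[C@]1(C(=O)N2CC[C@](c3ccc(C(F)(C(F)(F)F)C(F)(F)F)cc3)(S(=O)(=O)c3ccc(F)cc3)C2)CC[C@H](C(=O)O)CC1`: 95%
- compound 2 `O=C(O)[C@H]1CC[C@](F)(C(=O)N2CC[C@](c3ccc(C(F)(C(F)(F)F)C(F)(F)F)cc3)(S(=O)(=O)c3ccc(F)cc3)C2)CC1`: "not determined" (no result reported)
- compound 3 `CCC1(C(=O)N2CC[C@](c3ccc(C(F)(C(F)(F)F)C(F)(F)F)cc3)(S(=O)(=O)c3ccc(F)cc3)C2)CCS(=O)(=O)CC1`: 0%

In an ADME assay on microsomes from liver (Mus musculus) for metabolic stability, with a stated time of 10 min (a higher number here means that more of the compound is left, a lower number that less of the compound is left), compound 1 gives 95%, whereas compound 3 gives 0%; the step of a number 95 percentage points lower from compound 1 to compound 3 (beyond the scatter) is the only one measured. For compound 2 the result in this assay is "not determined" (no result reported), so compound 2 stands on no number and only its structure anchors the comparison.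

Compound 4 `O=C(N1CC[C@](c2ccc(C(F)(C(F)(F)F)C(F)(F)F)cc2)(S(=O)(=O)c2ccc(F)cc2)C1)C1(F)CCS(=O)(=O)CC1` differs from compound 2 by 4-fluoro-1,1-dioxothian-4-yl in place of 4-carboxy-1-fluorocyclohexyl on a carbonyl carbon. This parallels the change from compound 1 to compound 3, which was large and downward. A similarly large drop is therefore expected here, though with no starting value for compound 2 the estimate rests on compound 3 alone. Compound 4 is expected to give 5%, in the range 0% to 25%.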

Compound 4, percent of the compound remaining: 90%
Beside the measured number, compound 4's estimate is 85 percentage points below it; the whole stated range lies below it.
By their numbers in this assay, from the lowest: compound 3; then compounds 4 and 1 (each within the scatter of the next).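

In this assay fluoro in place of ethyl on a saturated ring carbon gives a number 90 percentage points higher from compound 3 to compound 4 (beyond the scatter) and so, in this pair, the group on that carbon sets the outcome, not the dioxothianyl ring alone. With a number 5 percentage points lower from compound 1 to compound 4 (within the scatter) the 4-fluoro-1,1-dioxothian-4-yl group stands level with 4-carboxy-1-methoxycyclohexyl on this carbonyl carbon, so the carboxy group is not required for a high value here. Nothing on hand gives a cause for either step. As far as these compounds go, whether a methyl or a hydroxyl group on that ring carbon reads like fluoro or like ethyl stays open, and any step from compound 2 cannot be read.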